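A few compounds are considered here, and "the series" means these few. Any claim that something is new, unique, unknown or untested is made for them only; others in the source may bear on it.

Compound 1 `O=C(Nc1ccc(S(=O)(=O)N2CCCCC2)c2ccccc12)c1ccccc1` and compound 2 `COCC(=O)N1CCC(NS(=O)(=O)c2ccc(NC(=O)c3ccccc3C)c3ccccc23)CC1` share a core and were tested in an assay on L1.2 cells for binding affinity to C-C chemokine receptor type 8 (Homo sapiens); a higher number here means a weaker inhibitor, a lower number a stronger inhibitor. Compound 1 gives only a limit of the assay, > 30000 nM, standing at the limit of > 30000 nM in this assay, at which 1 of the 2 values shown sits. Compound 2 gives 15.8 nM, the only number shown. Compound 3 `CCN(CC)CCCC(=O)N1CCC(NS(=O)(=O)c2ccc(NC(=O)c3ccccc3C)c3ccccc23)CC1` differs from compound 2 by 2-(diethylamino)ethyl in place of methoxy on a saturated chain carbon bound to a carbonyl carbon. Within the data shown here, no measured pair matches this change, so the step is expected to be no larger than the usual scatter, in either direction. The expected step is a 1.1-fold lower number from compound 2 to compound 3 (0.02 log units; within the scatter). For compound 3 the estimated value is 15 nM, with a range from 4 nM to 60 nM.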

Compound 3, inhibition constant: 567 nM
Compound 3: the middle estimate sits 38-fold (1.58 log units) below what was measured, and the stated range ends below it.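

In this assay the swap of methoxy for 2-(diethylamino)ethyl gives a 36-fold higher number from compound 2 to compound 3 (1.55 log units; beyond the scatter) and so shows that this place on the chain responds strongly to the group it carries. Even so, compound 3 still gives a real number, 567 nM, not a limit. Nothing shown here gives a cause for this step. Still open, going by these compounds, is whether the longer chain or its diethylamino end accounts for the step. A plain butyl chain in the same place, with no amine, would help separate the two.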